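Saturating the chain of a hydroxamic acid inhibitor

The compounds below may be only part of what the source reports. "The series", "measured", "known", "first", "only" and "open" are said of these compounds alone.

Of the compounds shown here, three have been tested in an assay on isolated protein for inhibition of histone deacetylase 8 (Homo sapiens); a higher number here means a weaker inhibitor, a lower number a stronger inhibitor. Compound 1 `COc1ccc(C(=O)CCCCCCCC(=O)NO)cc1` gives 15 nM, and compound 2 `O=C(CCCCCCCC(=O)c1ccc(N2CCN(c3ccccc3)CC2)cc1)NO` gives 4.5 nM. Compound 3 `C/C(=C\Cc1ccc(NS(=O)(=O)c2ccccc2)cc1)CC(=O)NO` gives 2000 nM, the highest number of the three; its gap to compound 1 and its larger gap to compound 2 both lie beyond the usual scatter, so compound 3 is the weakest inhibitor of this group.

Compound 4 `CC(CCc1ccc(NS(=O)(=O)c2ccccc2)cc1)CC(=O)NO` has not yet been measured in this assay. It differs from compound 3 in one place: a group of 8 heavy atoms (5 carbon, 1 nitrogen, 2 oxygen; no ring) in place of a group of 8 heavy atoms (5 carbon, 1 nitrogen, 2 oxygen; no ring), on a saturated chain carbon bound to an aromatic carbon. In plain words, the double bond that sits in the chain of compound 3 is removed, so the chain of compound 4 is fully saturated while keeping the same length and the same hydroxamic acid end group.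

Among the measured compounds shown here, no pair of measured compounds shows such a change, so there is no step to lean on. A change in the flexibility of the chain is expected to move the number only modestly, if at all, and in no clearly predicted direction. The step from compound 3 to compound 4 is estimated as a 1.3-fold higher number from compound 3 to compound 4 (0.10 log units; within the scatter), within or near the scatter. Compound 4 is therefore expected to give about 2500 nM in this assay, with a range from 800 nM to 8000 nM.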

Compound 4, half-maximal inhibitory concentration: 17000 nM
Estimate against measurement, compound 4: 6.8-fold (0.83 log units) below; measured number outside the range, above it.
By their numbers in this assay, from the lowest: compound 2; then compound 1; then compound 3; then compound 4.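

Among the compounds shown here, removing one double bond outside aromatic rings gives an 8.5-fold higher number from compound 3 to compound 4 (0.93 log units; beyond the scatter) in this assay and is the only change, on a saturated chain carbon bound to an aromatic carbon. For the compounds shown here, the heavy-atom count, the hydrogen-bond donors and acceptors and the net charge all stay the same, so this position in the chain is sensitive to its bonding alone, which the earlier compounds could not show with no pair among them differing in one place. Nothing measured here speaks to why the double bond matters.

As far as these compounds go, this is a single step on a single pair, so it remains unknown whether saturating the chain would have a similar effect on any other compound. From the compounds shown here alone, it is also open how a carbon-carbon triple bond at this place, the opposite geometry of the double bond or a longer chain carrying the same double bond would compare, and only such neighbours could show whether the double bond itself or its exact location sets the number.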